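This account rests on a few compounds, and the source may have more. Where it says the series, first, only, none or still open, it means among the compounds named here.

Compound 1 `O=C(O)/C(S)=C/c1ccc(I)cc1`: in an assay on isolated protein for inhibition of Calpain-1 catalytic subunit (Sus scrofa) (a higher number here means a weaker inhibitor, a lower number a stronger inhibitor), compound 1 gives 5200 nM
Compound 2 `O=C(O)/C(S)=C/c1ccc(Br)cc1`: in this assay compound 2 gives 1500 nM
Compound 3 `O=C(O)/C(S)=C/c1c[nH]c2c(I)cccc12`: in this assay compound 3 gives 220 nM

From compound 1 to compound 2 the change is bromo in place of iodo on an aromatic carbon and it gave a 3.5-fold lower number from compound 1 to compound 2 (0.54 log units; beyond the scatter). Compound 3 has the lowest number of the three; the difference between its core and the core of compound 1 is not broken down here. Compound 4 `O=C(O)/C(S)=C/c1c[nH]c2c(Br)cccc12` has not been measured. It differs from compound 3 by bromo in place of iodo on an aromatic carbon, the same kind of change as that from compound 1 to compound 2, though here the place is on an aromatic carbon of a six-membered aromatic ring of carbon only, part of a fused or bridged system of two rings, ortho to a fused ring and meta to a fused ring, rather than para to a group of 6 heavy atoms. Compound 4 is therefore expected to show a 2.4-fold lower number from compound 3 to compound 4 (0.39 log units; beyond the scatter), a step resting on the earlier one a 3.5-fold lower number from compound 1 to compound 2 (0.54 log units; beyond the scatter) but kept more cautious since the surroundings of the place are not the same. Compound 4 is estimated at 90 nM, between 30 nM and 300 nM.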

Compound 4, half-maximal inhibitory concentration: 70 nM
Estimate against measurement, compound 4: 1.3-fold (0.11 log units) above; the range from low to high includes it.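

On the core of compound 3, bromo in place of iodo gave a 3.1-fold lower number from compound 3 to compound 4 (0.50 log units; beyond the scatter) in this assay, so the change carried over to the second core with a matching size: the same change on two cores in this assay, a 3.5-fold lower number (0.54 log units; beyond the scatter) from compound 1 to compound 2 and a 3.1-fold lower number (0.50 log units; beyond the scatter) from compound 3 to compound 4, 1.1-fold (0.04 log units) apart, within the scatter of two such steps. This agreement shows that, for these two pairs, the step did not depend on which of the two cores carried it. Going by these compounds alone, it rests on only two pairs and one exchange of halogens, so it does not show that the step would hold on other cores or explain why bromo gives the lower number.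

The compounds shown leave open what chloro, fluoro or a plain hydrogen would give on the same aromatic carbon. They also leave open whether a methyl or methoxy group there would fit the same comparison.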